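Propyl in Place of Cyclopentyl on a Triazole Nitrogen

This account rests on a few compounds, and the source may have more. Where it says the series, first, only, none or still open, it means among the compounds named here.

Three compounds have been measured in a functional assay on RAW264.7 cells (Mus musculus) for inhibition, read by Griess assay, with stated times of 2 h and 24 h; a lower number here means a stronger inhibitor, a higher number a weaker inhibitor:
compound 1 `COc1ccc([C@@H]2CC(=O)c3c(O)cc(OCc4cn(C5CCCC5)nn4)cc3O2)cc1O` gives 10500 nM;
compound 2 `COc1ccc([C@@H]2C/C(=N\O)c3c(O)cc(OCc4cn(Cc5ccccc5Cl)nn4)cc3O2)cc1O` gives 13400 nM;
compound 3 `COc1ccc([C@@H]2C/C(=N\O)c3c(O)cc(OCc4cn(-c5ccccc5)nn4)cc3O2)cc1O` gives 6130 nM.

Compound 1 stands second highest of these three numbers. Its nearest neighbour is compound 2, and the gap between them lies within the scatter; the gap to compound 3 also lies within the scatter, so no order can be read among the three.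

Compound 4 `CCCn1cc(COc2cc(O)c3c(c2)O[C@H](c2ccc(OC)c(O)c2)CC3=O)nn1` has not yet been measured. It differs from compound 1 in one place: propyl in place of cyclopentyl on an aromatic nitrogen. Among the compounds with values here, the only step measured so far, a 2.2-fold lower number from compound 2 to compound 3 (0.34 log units; beyond the scatter), concerns a different group on the same aromatic nitrogen in compounds whose core carries an oxime rather than a ketone, so it bears on the present change only loosely. It shows that a swap of the group on this nitrogen moved the number modestly, no more.

Compound 4 is therefore expected to show a small change, a 1.1-fold higher number from compound 1 to compound 4 (0.06 log units; within the scatter), within the scatter, in this assay. The estimate for compound 4 is 12000 nM, with a range from 5000 nM to 30000 nM.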

Compound 4, half-maximal inhibitory concentration: 9670 nM
For compound 4 the middle estimate is 1.2-fold (0.09 log units) above the measured one, and the stated range covers the measured number.
By their numbers in this assay, from the lowest: compounds 3, 4, 1 and 2 (each within the scatter of the next, the first and the last beyond it).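

In this assay, replacing cyclopentyl with propyl on the aromatic nitrogen gives a 1.1-fold lower number from compound 1 to compound 4 (0.04 log units; within the scatter) and leaves the two compounds indistinguishable. Within the data shown here, this is the first direct comparison at this position on the ketone core, and it shows that removing the five-membered carbon ring and leaving an open chain of three carbons has no readable effect on the number in this pair. No supporting data explain why the two groups give such similar numbers.

Two groups made only of carbon cannot show whether this position would respond to a different kind of group, such as an amine or a carboxylic acid, or to a longer chain. On these data alone, it also remains open whether the modest step seen between the two oxime compounds would carry over to the ketone core.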